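The source may report more compounds than this note shows. Statements on the series, on what has been measured and on what is new or still open speak of the compounds shown alone.

The series shares one core, carried by compound 1 `COc1ccc(C(=O)/C=C/c2nc3ccccc3cc2-c2ccc(OC)cc2)cc1`, compound 2 `COc1ccc(-c2cc3ccccc3nc2/C=C/C(=O)c2ccc([N+](=O)[O-])cc2)cc1` and compound 3 `COc1ccc(-c2cc3ccccc3nc2/C=C/C(=O)c2ccc(Br)s2)cc1`, and the variation lies only in the group on the carbonyl carbon. In a functional assay on MDA-MB-231 cells (Homo sapiens) for antiproliferative activity, read by XTT assay, with a stated time of 72 h (a lower number here means a stronger inhibitor, a higher number a weaker inhibitor), compound 1 gives 7540 nM, and compound 2 gives 840 nM. For compound 3 the result is a limit of the assay, < 100 nM, so only a bound is known for compound 3 (the limit of < 100 nM in this assay, at which 1 of the 3 values shown sits). The step of a 9.0-fold lower number from compound 1 to compound 2 (0.95 log units; beyond the scatter) is modest, whereas an at least 75-fold lower number from compound 1 to compound 3 (1.87 log units; beyond the scatter) and an at least 8.4-fold lower number from compound 2 to compound 3 (0.92 log units; beyond the scatter) are larger, and both of those steps end at the limit, so their full size is not known.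

Compound 4 `COc1ccc(-c2cc3ccccc3nc2/C=C/C(=O)c2c[nH]c3ccccc23)cc1` carries the change (1H-indol-3-yl in place of 5-bromothiophen-2-yl on a carbonyl carbon). For the measured compounds named here, the measured steps all concern this same carbonyl position: the two substituted phenyl groups gave weaker inhibition than the 5-bromothiophen-2-yl group, and no measured compound carries an indole there, so the direction for compound 4 rests only on the spread already seen at that position. Compound 4 is therefore expected to sit in this assay at 400 nM, with a range from 80 nM to 2000 nM. This estimate means an expected step of an at least 4.0-fold higher number from compound 3 to compound 4 (0.60 log units; beyond the scatter), toward a weaker inhibitor, while leaving room for compound 4 to reach the limit as well.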

Compound 4, half-maximal inhibitory concentration: > 10000 nM
Compound 4 was reported as a limit; the forecaster's own chance of this, stated with the estimate: 20%; middle value at least 25-fold (1.39 log units) from the limit.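

Placing 1H-indol-3-yl on the carbonyl carbon shows that this position can weaken the series as well as strengthen it, with an at least 100-fold higher number from compound 3 to compound 4 (2.00 log units; beyond the scatter) and an at least 11-fold higher number from compound 2 to compound 4 (1.07 log units; beyond the scatter) in this assay. Against the 4-methoxyphenyl group the result gives only an at least 1.3-fold higher number from compound 1 to compound 4 (0.12 log units; that floor lies within the scatter), so the data do not establish that the 1H-indol-3-yl group is worse than that group, only that both lie at the weak end of the series. Compound 4 stands at a limit of the assay, so the weak end of the range at this position has no measured value: the limit of > 10000 nM in this assay, at which 1 of the 4 values shown sits.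

Compound 3 also stands at a limit of the assay, so the strong end is equally unfixed and the full span at this position remains unknown: the limit of < 100 nM in this assay, at which 1 of the 4 values shown sits. The compounds shown also leave open whether the change in compound 4 follows from the bromine leaving, the indole nitrogen hydrogen entering or the added six-membered ring, a question that an unsubstituted thiophen-2-yl group or a 1-methylindol-3-yl group on the carbonyl carbon would help to separate.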